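Fluorine in Place of a Nitroso Group: An Expectation

The compounds below may be only part of what the source reports. "The series", "measured", "known", "first", "only" and "open" are said of these compounds alone.

In an assay on isolated protein for binding affinity to corticotropin-releasing factor receptor 1 (Homo sapiens) (a lower number here means a stronger inhibitor, a higher number a weaker inhibitor), compound 1 `CCCN(CCC)c1cc(C)nc2c(-c3ncc(N)cc3C)c(C)nn12` gives 85 nM, compound 2 `CCCN(CCC)c1cc(C)nc2c(-c3ncc(NC)cc3C)c(C)nn12` gives 40 nM, and compound 3 `CCCN(CCC)c1cc(C)nc2c(-c3ncc(N=O)cc3C)c(C)nn12` gives 100 nM, which stands at the top of the three numbers, although its gap to compound 1 is within the scatter. Compound 4 `CCCN(CCC)c1cc(C)nc2c(-c3ncc(F)cc3C)c(C)nn12` differs from compound 3 by one fluorine atom in place of a group of 2 heavy atoms (1 nitrogen, 1 oxygen; no ring), on an aromatic carbon, a change not yet measured. The steps touching that same aromatic carbon are a 1.2-fold higher number from compound 1 to compound 3 (0.07 log units; within the scatter) and a 2.5-fold higher number from compound 2 to compound 3 (0.40 log units; beyond the scatter), so small groups there move this assay only modestly. Among the measured compounds shown here, no fluoro compound is known here, so the expected step is a 1.3-fold lower number from compound 3 to compound 4 (0.10 log units; within the scatter), within the scatter. Compound 4 is therefore estimated at 80 nM, with a range from 30 nM to 250 nM.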

Compound 4, inhibition constant: 19 nM
Beside the measured number, compound 4's estimate is 4.2-fold (0.62 log units) above it; measured number below the stated range.
By their numbers in this assay, from the lowest: compound 4; then compound 2; then compounds 1 and 3 (each within the scatter of the next).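

In this assay, among the compounds shown here, this position proves able to give a larger move than the earlier steps showed: replacing the nitroso group with fluoro gives a 5.3-fold lower number from compound 3 to compound 4 (0.72 log units; beyond the scatter). Fluoro also improves on both nitrogen groups, with a 2.1-fold lower number from compound 2 to compound 4 (0.32 log units; beyond the scatter) in place of methylamino and a 4.5-fold lower number from compound 1 to compound 4 (0.65 log units; beyond the scatter) in place of amino. Compound 4 therefore has the lowest number of the four, and nothing available here explains why. From the compounds shown here alone, whether chlorine, methoxy or trifluoromethyl on this same carbon would match or pass fluoro remains open.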